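A Chloro Group Added to the Benzyl Ring of Compound 3

The source may hold more compounds than are shown below. What is called first, only, known or untested is meant among the compounds shown, and "the series" means these compounds.

Compound 3 `CCC(C(=O)NCc1ccccc1)N1C(=O)CCC1=O` was tested in a functional assay on the whole organism (strain Albino Swiss CD1) with Mus musculus as the target (a higher number here means that more compound is needed for the effect, a lower number that less compound is needed), where it gives 90.3 mg/kg. This is the higher of the two numbers available: compound 2 `CC(C(=O)NCc1ccc(Cl)cc1)N1C(=O)CCC1=O` gives 43.6 mg/kg in this assay, a difference beyond the usual scatter, so compound 2 needs less material for the same effect. Compound 1 `CC(C(=O)NCc1ccccc1Cl)N1C(=O)CCC1=O` stands at "not determined" (no result reported) in this assay. Compound 4 `CCC(C(=O)NCc1cccc(Cl)c1)N1C(=O)CCC1=O` differs from compound 3 only by chloro in place of hydrogen on an aromatic carbon. Among the measured compounds shown here, no measured pair isolates this single change, and compound 2 also carries a methyl instead of an ethyl chain, so any guidance from it is indirect. The expected step of a 1.5-fold lower number from compound 3 to compound 4 (0.18 log units; within the scatter) is a modest one towards a lower number. The estimate for compound 4 is 60 mg/kg, with a range from 30 mg/kg to 120 mg/kg.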

Compound 4, dose for half-maximal effect: 78.9 mg/kg
Beside the measured number, compound 4's estimate is 1.3-fold (0.12 log units) below it; the measured number falls inside the stated range.
By their numbers in this assay, from the lowest: compounds 2, 4 and 3 (each within the scatter of the next, the first and the last beyond it).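

Among the compounds shown here, replacing phenyl with 3-chlorophenyl is the first change that can be read on its own, and in this assay it gives a clear answer (a 1.1-fold lower number from compound 3 to compound 4 (0.06 log units; within the scatter)). At this place on the ring, chloro in place of hydrogen therefore produces no change that can be told apart from scatter. No measurement here offers an explanation for this result.

On these data alone, whether a methoxy group at this place, or a propyl chain in place of the ethyl chain, would give a real change stays open. Compound 2 differs from compound 4 in more than one place, so it cannot settle the role of the chloro position.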